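Moving the Methyl Group on the Phenyl Ring

The compounds below may be only part of what the source reports. "The series", "measured", "known", "first", "only" and "open" are said of these compounds alone.

Compound 1 `Clc1ccc(-c2cc(-c3ccsc3)nc(-c3ccco3)c2)o1`: > 50000 nM
Compound 2 `Clc1ccc(-c2cc(-c3ccsc3)nc(-c3ccccc3Cl)c2)o1`: 4570 nM
Compound 3 `Cc1cccc(-c2cc(-c3ccc(Cl)o3)cc(-c3ccsc3)n2)c1`: 21700 nM

All three were tested in a functional assay on HCT-15 cells (Homo sapiens) for cytotoxicity, in the presence of a further agent that is not named here; a lower number here means a stronger inhibitor, a higher number a weaker inhibitor. The value for compound 1 is a limit of the assay rather than a number (the limit of > 50000 nM in this assay, at which 1 of the 3 values shown sits). Of the two true numbers, compound 3 stands highest; the gap to its nearest neighbour is a 4.7-fold higher number from compound 2 to compound 3 (0.68 log units; beyond the scatter). Compound 3 carries a 3-methylphenyl group on the shared core, compound 2 a 2-chlorophenyl group at the same place, and compound 1 a furan-2-yl group.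

Compound 4 `Cc1ccccc1-c1cc(-c2ccc(Cl)o2)cc(-c2ccsc2)n1` is built from the same atoms as compound 3, joined differently: 2-methylphenyl in place of 3-methylphenyl on an aromatic carbon. For the measured compounds named here, two measured steps bear on this change, both at the same aromatic carbon: an at least 2.3-fold lower number from compound 1 to compound 3 (0.36 log units; beyond the scatter) and a 4.7-fold higher number from compound 2 to compound 3 (0.68 log units; beyond the scatter). The second of these mixes two changes at once, chlorine for methyl and a shift of the substituent's place on the phenyl ring, so only part of it can be credited to the shift itself. With that caution, a modest lowering of the number is expected for compound 4, an expected step of a 2.4-fold lower number from compound 3 to compound 4 (0.38 log units; beyond the scatter). Compound 4 is therefore estimated at 9000 nM, with a range from 3000 nM to 30000 nM.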

Compound 4, half-maximal inhibitory concentration: 4630 nM
Estimate against measurement, compound 4: 1.9-fold (0.29 log units) above, and the stated range covers the measured number.
By their numbers in this assay, from the lowest: compounds 2 and 4 (each within the scatter of the next); then compound 3. At a limit, above all of these: compound 1.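

For the compounds shown here, compound 3 and compound 4 have the same atoms and differ only in where the methyl group sits on the phenyl ring, and in this assay this shift gives a 4.7-fold lower number from compound 3 to compound 4 (0.67 log units; beyond the scatter), so the place of the methyl counts by itself, which the earlier compounds could not show apart from a change of group. With the substituent held at the same place on the phenyl ring, methyl in place of chloro gives a 1.0-fold higher number from compound 2 to compound 4 (0.01 log units; within the scatter), so in this pair the exchange of one group for the other leaves the number within the scatter. Compound 1 carries a limit of the assay rather than a number, so 2-methylphenyl in place of its furan-2-yl group can only be read as a lower bound on the change, an at least 10-fold lower number from compound 1 to compound 4 (1.03 log units; beyond the scatter).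

Nothing shown here explains why the place of the methyl group matters in this way. Going by these compounds, how the number would respond to a longer chain such as ethyl, or to an amine or a carboxylic acid on the same phenyl ring, remains open.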